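Side-chain ester variants on a shared bisindolylmaleimide-type core

The source may report more compounds than this note shows. Statements on the series, on what has been measured and on what is new or still open speak of the compounds shown alone.

Compound 1 `COC(=O)[C@H](NC(=O)Cn1cc(C2=C(c3c[nH]c4ccccc34)C(=O)N(C)C2=O)c2ccccc21)[C@@H](C)O` carries, on its amide-linked amino-acid portion, a 1-hydroxyethyl group. In a functional assay on A2780 cells (Homo sapiens) for cytotoxicity, read by MTT assay, with a stated time of 24 h (a lower number here means a stronger inhibitor, a higher number a weaker inhibitor), compound 1 gives 21400 nM. Two close relatives have been measured alongside it. Compound 2 `COC(=O)[C@@H](CO)NC(=O)Cn1cc(C2=C(c3c[nH]c4ccccc34)C(=O)N(C)C2=O)c2ccccc21` gives 23200 nM in this assay, and compound 3 `COC(=O)[C@@H](CC(C)C)NC(=O)Cn1cc(C2=C(c3c[nH]c4ccccc34)C(=O)N(C)C2=O)c2ccccc21` gives 38500 nM in this assay. The number for compound 1 is the lowest of the three, but the gaps to the others are within the scatter, so none of the three can be called stronger or weaker: the change a 1.1-fold higher number from compound 1 to compound 2 (0.04 log units; within the scatter), the change a 1.8-fold higher number from compound 1 to compound 3 (0.26 log units; within the scatter), and the change a 1.7-fold higher number from compound 2 to compound 3 (0.22 log units; within the scatter) all fall within repeat-measurement noise.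

Compound 4 `COC(=O)C[C@@H](NC(=O)Cn1cc(C2=C(c3c[nH]c4ccccc34)C(=O)N(C)C2=O)c2ccccc21)C(=O)OC` is the next step from compound 1: (methoxycarbonyl)methyl in place of 1-hydroxyethyl on a saturated chain carbon bound to an amide-type nitrogen and a carbonyl carbon. Going by the values given here, both measured steps that touch this side chain, the one to compound 3 and the one to compound 2, show that swapping the hydroxy-bearing group for something else moved the number only within the scatter. The new group is again a small, uncharged side chain, so no step beyond the scatter is expected, and the move a 1.2-fold higher number from compound 1 to compound 4 (0.08 log units; within the scatter) is the estimate. Compound 4 is therefore expected to give about 26000 nM in this assay, with a likely range from 11000 nM to 60000 nM.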

Compound 4, half-maximal inhibitory concentration: 15400 nM
Beside the measured number, compound 4's estimate is 1.7-fold (0.23 log units) above it; measured number inside the range.
By their numbers in this assay, from the lowest: compounds 4, 1, 2 and 3 (each within the scatter of the next, the first and the last beyond it).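

In this assay, this position now shows its first step beyond the scatter (a 2.5-fold lower number from compound 3 to compound 4 (0.40 log units; beyond the scatter)), a modest one, so the group on a saturated chain carbon bound to an amide-type nitrogen and a carbonyl carbon can move the number, at least between these two compounds. The other two steps stay within the scatter (a 1.4-fold lower number from compound 1 to compound 4 (0.14 log units; within the scatter)) and (a 1.5-fold lower number from compound 2 to compound 4 (0.18 log units; within the scatter)), so replacing a hydroxy-bearing side chain with (methoxycarbonyl)methyl, which has 0 hydrogen-bond donors and 2 hydrogen-bond acceptors, does not set compound 4 apart from compound 1 or compound 2. Nothing measured here explains why compound 3 and compound 4 lie further apart than the other pairs.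

All four side chains shown carry no net charge, so it remains open how the number would respond at this place to a free carboxylic acid or an amine. Also open, as far as these compounds go, is whether a longer chain ending in methoxycarbonyl would extend the gap from compound 3 or leave the number within the scatter of compound 4.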